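The source may hold more compounds than are shown below. What is called first, only, known or untested is meant among the compounds shown, and "the series" means these compounds.

Within the data shown here, the two compounds measured so far share one core and differ only in the saturated five-membered ring that caps one end of it. Compound 1 `Nc1ccccc1NC(=O)c1ccc(CNC2=N[C@@H](c3ccccc3)CN2)cc1` gives 78% in an assay on isolated protein for inhibition of protein deacetylase HDAC6 (Homo sapiens), read by fluorescence, with a stated time of 1 h, tested at 20 uM; a lower number here means less inhibition, a higher number more inhibition at the concentration tested (going by the name of the read-out). Compound 2 `Nc1ccccc1NC(=O)c1ccc(CNC2=N[C@@H](Cc3ccccc3)CO2)cc1` gives 72% in this assay. Compound 2 sits at the lower of the two numbers, yet the gap to compound 1 is within the usual scatter of repeated measurements, so the two cannot be told apart on inhibition. Compound 3 `Nc1ccccc1NC(=O)c1ccc(CNC2=N[C@@H](c3ccc(O)cc3)CO2)cc1` has not yet been measured. It differs from compound 2 in one place: 4-hydroxyphenyl in place of benzyl on a saturated ring carbon. Among the measured compounds shown here, no measured pair shows this change, so there is nothing to lean on for its size. The expectation for compound 3 is a step of a number 2 percentage points lower from compound 2 to compound 3 (within the scatter) that stays within the scatter, in no clear direction. The estimate for compound 3 in this assay is therefore 70%, expected to fall between 50% and 85%.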

Compound 3, a percentage reported as inhibition, at one concentration (the size of the read-out at that concentration, not a potency) in the protein deacetylase HDAC6 assay: 13%
For compound 3 the middle estimate is 57 percentage points above the measured one; measured number below the stated range.
By their numbers in the protein deacetylase HDAC6 assay, from the lowest: compound 3; then compounds 2 and 1 (each within the scatter of the next).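

This carbon of the saturated ring is not indifferent to what it carries: in the protein deacetylase HDAC6 assay, the step is large, a number 59 percentage points lower from compound 2 to compound 3 (beyond the scatter). The near-equal numbers of the two earlier compounds gave no hint of such sensitivity, yet here a group of the same heavy-atom count removes most of the inhibition. The change also takes the compound towards the polar end of a physicochemical assay for lipophilicity, read by HPLC; a lower number here means a more polar compound, a higher number a more lipophilic compound (compound 2 gives 2.86 and compound 3 gives 1.74), which may be part of the loss, though one pair cannot prove it: the measured distribution coefficient of compound 2, 2.86, and of compound 3, 1.74, a number 1.12 log units lower (beyond the scatter)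

The change does two things at once, removing the one-carbon link to the aromatic ring and adding a hydroxyl, and the compounds shown do not separate them. A 4-hydroxybenzyl or a plain phenyl on this carbon would tell the two apart, and a 4-methoxyphenyl would test the hydroxyl hydrogen.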